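Sulfonyl substituent swap and liver microsomal stability

The source may report more compounds than this note shows. Statements on the series, on what has been measured and on what is new or still open speak of the compounds shown alone.

Values in an ADME assay on microsomes from liver (Homo sapiens) for metabolic stability, read by LC-MS, with a stated time of 30 min, tested at 1 uM; on this read-out lower numbers stand for a less stable compound and higher numbers for a more stable compound:
compound 1 `O=C(NCc1ccc(S(=O)(=O)N2CCCCC2)cc1)c1cnc2nccn2c1`: 64%
compound 2 `O=C(NCc1ccc(S(=O)(=O)c2cccc(C(F)(F)F)c2)cc1)c1cc2ccncc2o1`: 48%
compound 3 `O=C(NCc1ccc(S(=O)(=O)c2cccc(C(F)(F)F)c2)cc1)c1cnc2nccn2c1`: 41%

Compound 3 and compound 1 differ by piperidin-1-yl in place of 3-(trifluoromethyl)phenyl on a sulfonyl sulfur, and the step in this assay is a number 23 percentage points higher from compound 3 to compound 1 (beyond the scatter). The two cores differ by a group of 9 heavy atoms (7 carbon, 1 nitrogen, 1 oxygen; one five-membered aromatic ring with 1 hetero atom, one six-membered aromatic ring with 1 hetero atom) in place of a group of 9 heavy atoms (6 carbon, 3 nitrogen; one five-membered aromatic ring with 2 hetero atoms, one six-membered aromatic ring with 2 hetero atoms), on a carbonyl carbon; the step in this assay is a number 7 percentage points lower from compound 2 to compound 3 (within the scatter), so the core swap itself is not resolved here.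

Compound 4 `O=C(NCc1ccc(S(=O)(=O)N2CCCCC2)cc1)c1cc2ccncc2o1` is not yet measured. It differs from compound 2 by piperidin-1-yl in place of 3-(trifluoromethyl)phenyl on a sulfonyl sulfur, the same change as from compound 3 to compound 1, with the same surroundings at the place. The expected step in this assay for compound 4 is a number 22 percentage points higher from compound 2 to compound 4 (beyond the scatter), because a number 23 percentage points higher from compound 3 to compound 1 (beyond the scatter) was seen for the same change at the same place; a single precedent keeps the range wide. Compound 4 is therefore estimated at 70%, expected between 55% and 85%.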

Compound 4, percent of the compound remaining: 56%
The estimate for compound 4 lay 14 percentage points above the measured number; low and high end bracket the measured number.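

In this assay, piperidin-1-yl in place of 3-(trifluoromethyl)phenyl on the sulfonyl sulfur gives a number 8 percentage points higher from compound 2 to compound 4 (within the scatter), so the size of the step on the core of compound 1 does not carry over to the core of compound 2: the same change on two cores in this assay, a number 23 percentage points higher (beyond the scatter) from compound 3 to compound 1 and a number 8 percentage points higher (within the scatter) from compound 2 to compound 4, 15 percentage points apart, beyond the scatter of two such steps
Read the other way, the core swap gives a number 8 percentage points lower from compound 1 to compound 4 (within the scatter), and the two core steps do not match across the two sulfonyl substituents: the same change on two cores in this assay, a number 7 percentage points lower (within the scatter) from compound 2 to compound 3 and a number 8 percentage points higher (within the scatter) from compound 4 to compound 1, 15 percentage points apart, beyond the scatter of two such steps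
With one pair on each core, this shows that the step depends on the core in this series, but it gives no rule for predicting its size on a further core.

Open, on these data alone, is how a morpholine ring or a diethylamino group on the sulfonyl sulfur would read on either core.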